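Trading an aminomethyl-bearing chain for cyclohexyl at an amide carbonyl

The compounds below may be only part of what the source reports. "The series", "measured", "known", "first", "only" and "open" are said of these compounds alone.

Measured compounds:
Compound 1 `N#Cc1ccc(N2CCC(C(=O)N3N=CC[C@H]3c3cc(F)cc(F)c3)CC2)nn1` gives 4.8 in a physicochemical assay for lipophilicity, read by HPLC, measured as chromatographic lipophilicity, at pH 7.4; a lower number here means a more polar compound, a higher number a more lipophilic compound.
Compound 2 `CC(C)(CN)C(=O)N1N=CCC1c1ccccc1` gives 1.4 in this assay.
Compound 3 `CC(C)(C)C(=O)N1CCNCC1c1ccccc1` gives 2.5 in this assay.

Among these three, compound 2 stands lowest. Compound 3 comes nearest to it but gives a higher number, beyond the scatter, and compound 1 gives by far the highest number, also beyond the scatter. No two of the three compounds differ in only one place, so no single measured step can be read from them.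

Compound 4 `O=C(C1CCCCC1)N1N=CCC1c1ccccc1` has not yet been measured in this assay. It differs from compound 2 in one place: cyclohexyl in place of 1-(aminomethyl)-1-methylethyl on a carbonyl carbon. The group that leaves carries one hydrogen-bond donor and one hydrogen-bond acceptor; the cyclohexyl that enters carries neither and holds one more heavy atom.

A sizeable upward step in this assay is expected, well beyond the scatter, because compound 2 gives 1.4 and both other compounds, which lack such an amine-bearing chain on the carbonyl, give higher numbers. The expected step is a number 2.80 log units higher from compound 2 to compound 4 (beyond the scatter). Compound 4 is estimated to give about 4.2, with a likely range from 3.6 to 4.8.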

Compound 4, distribution coefficient: 5.9
Beside the measured number, compound 4's estimate is 1.70 log units below it; measured number above the stated range.
By their numbers in this assay, from the lowest: compound 2; then compound 3; then compound 1; then compound 4.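

In this assay, putting cyclohexyl in place of 1-(aminomethyl)-1-methylethyl on a carbonyl carbon whose other neighbour is an amide-type nitrogen in a ring gives a number 4.50 log units higher from compound 2 to compound 4 (beyond the scatter), the first single-place step available among these compounds. With the rest of the shared core unchanged, this one position can therefore carry a large change in the read-out. The swap alters several features at once, however: the group that leaves has a nitrogen, a hydrogen-bond donor and a hydrogen-bond acceptor and no ring, whereas cyclohexyl has no donor or acceptor and is a six-membered ring of carbon only, so this single step cannot divide its size among those features.

The compounds shown leave open which of those features matters most, a question that an open-chain hexyl group or a piperidine ring on the same carbonyl carbon could help to separate. Nothing available here explains why the step is this large.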